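Replacing the Chloropyrazole on a Shared Chemokine Antagonist Core

A few compounds are considered here, and "the series" means these few. Any claim that something is new, unique, unknown or untested is made for them only; others in the source may bear on it.

Of the compounds shown here, three built on one core have been measured in a functional assay on Venous blood for antagonist activity at C-X-C chemokine receptor type 3 (Homo sapiens), read by flow cytometry, with a stated time of 30 min, in the presence of a further agent that is not named here; on this read-out higher numbers stand for weaker inhibition and lower numbers for stronger inhibition. Compound 1 `C[C@@H]1CN(c2sc(C(F)(F)F)nc2-c2nc3ccccc3[nH]2)CCN1C(=O)Cn1ccc(C(=O)O)n1` gives 5570 nM, compound 2 `C[C@@H]1CN(c2sc(C(F)(F)F)nc2-c2nc3ccccc3[nH]2)CCN1C(=O)CN1C(=O)OC[C@@H]1c1ccccc1` gives 1380 nM, and compound 3 `C[C@@H]1CN(c2sc(C(F)(F)F)nc2-c2nc3ccccc3[nH]2)CCN1C(=O)Cn1cc(Cl)cn1` gives 251 nM, the lowest number of the three. Compound 4 `C[C@@H]1CN(c2sc(C(F)(F)F)nc2-c2nc3ccccc3[nH]2)CCN1C(=O)Cn1cnc2c1CCN(C)C2` differs from compound 3 by a group of 10 heavy atoms (7 carbon, 3 nitrogen; one five-membered aromatic ring with 2 hetero atoms, one six-membered non-aromatic ring with 1 hetero atom) in place of a group of 6 heavy atoms (3 carbon, 2 nitrogen, 1 chlorine; one five-membered aromatic ring with 2 hetero atoms), on a saturated chain carbon bound to a carbonyl carbon. Among the measured compounds shown here, the steps that bear on this exchange are those at the same position: a 22-fold lower number from compound 1 to compound 3 (1.35 log units; beyond the scatter) and a 5.5-fold lower number from compound 2 to compound 3 (0.74 log units; beyond the scatter). Every exchange at this carbon so far has shifted the number well beyond the scatter, so a shift beyond the scatter is expected for compound 4 too, although the three measured compounds do not fix its direction. Compound 4 is therefore estimated at 600 nM, within a range of 150 nM to 2500 nM, a step of a 2.4-fold higher number from compound 3 to compound 4 (0.38 log units; beyond the scatter).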

Compound 4, half-maximal inhibitory concentration: 135 nM
Estimate against measurement, compound 4: 4.4-fold (0.65 log units) above, outside the stated range (below it).
By their numbers in this assay, from the lowest: compounds 4 and 3 (each within the scatter of the next); then compound 2; then compound 1.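

In this assay, among the compounds shown here, the larger group with its added six-membered non-aromatic ring gives a 1.9-fold lower number from compound 3 to compound 4 (0.27 log units; within the scatter), the first exchange at this carbon that stays within the scatter, so the chlorine is not needed to reach this level. The same group gives a 10-fold lower number from compound 2 to compound 4 (1.01 log units; beyond the scatter) and a 41-fold lower number from compound 1 to compound 4 (1.62 log units; beyond the scatter), which places compound 4 level with compound 3 and clear of the other two. No measurement shown here explains this result.

On these data alone, it remains open whether a 1H-pyrazol-1-yl group carrying a dimethylamino group would match the entering group. The same holds for a morpholine ring on a longer chain at this carbon.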